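Changing the Pendant Ring on a Shared Core

A few compounds are considered here, and "the series" means these few. Any claim that something is new, unique, unknown or untested is made for them only; others in the source may bear on it.

Compound 1, `OC[C@H]1OC(n2cnc3c(-c4ccco4)ncnc32)[C@H](O)[C@@H]1O`, gives 2000 nM in a functional assay on L1210 cells (Mus musculus) for inhibition; on this read-out higher numbers stand for weaker inhibition and lower numbers for stronger inhibition. Compound 2, `OC[C@H]1OC(n2cnc3c(-c4cc[nH]c4)ncnc32)[C@H](O)[C@@H]1O`, gives 17500 nM in this assay. Compound 3, `OC[C@H]1OC(n2cnc3c(-c4ccc(O)cc4)ncnc32)[C@H](O)[C@@H]1O`, gives 5000 nM in this assay.

Among these three numbers compound 3 stands second highest: the step of a 2.5-fold higher number from compound 1 to compound 3 (0.40 log units; beyond the scatter) puts compound 1 below it, and the step of a 3.5-fold lower number from compound 2 to compound 3 (0.54 log units; beyond the scatter) puts compound 2 above it. The three compounds share the same core and differ only in the ring attached to it.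

Compound 4, `OC[C@H]1OC(n2cnc3c(-c4nccs4)ncnc32)[C@H](O)[C@@H]1O`, differs from compound 3 in one place: 1,3-thiazol-2-yl in place of 4-hydroxyphenyl on an aromatic carbon. Among the compounds with values here, two measured steps bear on this move. The step of a 2.5-fold higher number from compound 1 to compound 3 (0.40 log units; beyond the scatter) shows that replacing furan-2-yl by 4-hydroxyphenyl raised the number modestly, so going back from 4-hydroxyphenyl toward a small ring that enters through a carbon flanked by a hetero atom, as furan-2-yl does, should lower it by a similar modest amount. The step of an 8.8-fold higher number from compound 1 to compound 2 (0.94 log units; beyond the scatter) warns that not every small ring behaves like furan-2-yl, since 1H-pyrrol-3-yl gave a far higher number. The thiazol-2-yl entering here carries its hetero atoms in the manner of furan-2-yl rather than 1H-pyrrol-3-yl, so a modest drop is expected in this assay, about a 2.0-fold lower number from compound 3 to compound 4 (0.30 log units; within the scatter). Compound 4 is therefore estimated at 2500 nM, with a range from 800 nM to 8000 nM.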

Compound 4, half-maximal inhibitory concentration: 16000 nM
Compound 4: middle estimate off by 6.4-fold (0.81 log units), on the low side; measured number above the stated range.
By their numbers in this assay, from the lowest: compound 1; then compound 3; then compounds 4 and 2 (each within the scatter of the next).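

Placing 1,3-thiazol-2-yl on this aromatic carbon gives an 8.0-fold higher number from compound 1 to compound 4 (0.90 log units; beyond the scatter), so in this assay a five-membered aromatic ring with hetero atoms does not by itself match furan-2-yl. The same ring also gives a 3.2-fold higher number from compound 3 to compound 4 (0.51 log units; beyond the scatter), and a 1.1-fold lower number from compound 2 to compound 4 (0.04 log units; within the scatter) leaves 1,3-thiazol-2-yl and 1H-pyrrol-3-yl indistinguishable, so among these four compounds ring size does not set the order: the six-membered 4-hydroxyphenyl ring of compound 3 falls between furan-2-yl and the two other five-membered rings. Nothing available explains why these rings differ at this position.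

As far as these compounds go, it remains open whether the lowest number, that of compound 1, is specific to furan-2-yl or would also be reached by a closely related ring such as thiophen-2-yl. A plain phenyl ring would show what the hydroxyl group of compound 3 contributes, and an amine on the same carbon would show whether a ring is needed here at all.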